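Swapping a Methyl for Fluorine on the Pendant Ring

The compounds below may be only part of what the source reports. "The series", "measured", "known", "first", "only" and "open" are said of these compounds alone.

Compound 3 `CNC(=O)c1cc(C(=O)NC2CC2)cn(Cc2ccc(C)cc2)c1=O` gives 3.5 in a physicochemical assay for lipophilicity, at pH 7.4 (on this read-out lower numbers stand for lower lipophilicity and higher numbers for higher lipophilicity), the highest of the three measured numbers. Compound 1 `CNC(=O)c1cc(C(=O)NC2CC2)cn(Cc2cccc(OC)c2)c1=O` gives 3 in this assay, and compound 2 `CNC(=O)c1cc(C(=O)NC2CC2)cn(Cc2cccc3[nH]ccc23)c1=O` gives 2.9. The steps up to the top were a number 0.50 log units higher from compound 1 to compound 3 (beyond the scatter) and a number 0.60 log units higher from compound 2 to compound 3 (beyond the scatter). Compound 4 `CNC(=O)c1cc(C(=O)NC2CC2)cn(Cc2ccccc2F)c1=O` differs from compound 3 by 2-fluorophenyl in place of 4-methylphenyl on a saturated chain carbon bound to an aromatic nitrogen. Among the compounds with values here, no measured step involves a 2-fluorophenyl, so nothing bears on this change directly; the two steps into compound 3 show only that exchanging the group at this place moved the read-out modestly. Compound 4 is expected to sit somewhat lower, by a number 0.40 log units lower from compound 3 to compound 4 (beyond the scatter). Compound 4 is therefore estimated at 3.1, in a range from 2.7 to 3.5.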

Compound 4, distribution coefficient: 3
Beside the measured number, compound 4's estimate is 0.10 log units above it; low and high end bracket the measured number.
By their numbers in this assay, from the lowest: compounds 2, 1 and 4 (each within the scatter of the next); then compound 3.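

In this assay, 2-fluorophenyl in place of 4-methylphenyl gives (a number 0.50 log units lower from compound 3 to compound 4 (beyond the scatter)), so this new group does not share the high reading of compound 3. Against the other two groups the steps are (a number 0.10 log units higher from compound 2 to compound 4 (within the scatter)) and (no change at the digits printed from compound 1 to compound 4 (within the scatter)), so three different groups on a saturated chain carbon bound to an aromatic nitrogen now read alike, and only 4-methylphenyl stands apart. No measurement shown explains this grouping.

Still open, going by these compounds, is how a plain phenyl, or a ring carrying an amine or a carboxylic acid, would read at this place.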